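The source may hold more compounds than are shown below. What is called first, only, known or untested is meant among the compounds shown, and "the series" means these compounds.

Compound 1 `CC(=O)N1CCC(n2cc(-c3cnc(N)c4oc(-c5cccc6cnsc56)cc34)cn2)CC1`: 0.84
Compound 2 `CC(=O)N1CCC(n2cc(-c3cnc(N)c4oc(-c5cn(C)c6cnccc56)cc34)cn2)CC1`: 0.91

Both compounds were tested in an ADME assay on microsomes from liver (Mus musculus) for metabolic stability; a lower number here means that the liver removes a smaller share, a higher number that the liver removes a larger share of the compound in one pass. In this assay compound 1 gives 0.84, and compound 2 gives 0.91. The two numbers lie within the scatter of each other, the step being a number 0.070 higher from compound 1 to compound 2 (within the scatter), so neither compound can be called more or less stable than the other on this evidence.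

Compound 3 `CC(=O)N1CCC(n2cc(-c3cnc(N)c4oc(-c5csc6cnccc56)cc34)cn2)CC1` has not yet been measured. It differs from compound 2 in one place: a group of 9 heavy atoms (7 carbon, 1 nitrogen, 1 sulfur; one five-membered aromatic ring with 1 hetero atom, one six-membered aromatic ring with 1 hetero atom) in place of a group of 10 heavy atoms (8 carbon, 2 nitrogen; one five-membered aromatic ring with 1 hetero atom, one six-membered aromatic ring with 1 hetero atom), on an aromatic carbon. Among the measured compounds shown here, the only measured step that bears on a swap of this kind is the one between compound 1 and compound 2, which also exchanges one fused two-ring group for another on the same aromatic carbon of the shared core, and that step stayed within the scatter. A change of a similar kind is therefore expected to stay within the scatter as well, with no clear direction.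

Compound 3 is thus estimated to come out near 0.87, between 0.76 and 0.96. The expected step is a number 0.040 lower from compound 2 to compound 3 (within the scatter).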

Compound 3, hepatic extraction ratio: 0.72
Estimate against measurement, compound 3: 0.15 above; measured number below the stated range.
By their numbers in this assay, from the lowest: compound 3; then compounds 1 and 2 (each within the scatter of the next).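

The fused two-ring group on this aromatic carbon, next to the ring oxygen, can shift the result in this assay beyond the scatter, something the first two compounds gave no sign of. Exchanging the group with two nitrogens for the one with sulfur gives a number 0.19 lower from compound 2 to compound 3 (beyond the scatter) and leaves the ring types and the hetero atom count of each ring the same. The group of compound 1 and the group of compound 3 hold the same counts of carbon, nitrogen and sulfur, yet their different arrangement gives a number 0.12 lower from compound 1 to compound 3 (beyond the scatter) and so atom counts alone do not set the number among these compounds.

No available measurement explains why the arrangement of these atoms matters. From the compounds shown here alone, whether a plain phenyl ring, or an oxygen in place of the sulfur in the group of compound 3, would bring the number lower still remains open.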